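Solubility of a Shared Amide Core with Varied Ether Tails

The source may report more compounds than this note shows. Statements on the series, on what has been measured and on what is new or still open speak of the compounds shown alone.

Measured compounds:
compound 1, `CN1CCC(Oc2ccc(-c3nc4cc(C(N)=O)ccc4[nH]3)cc2)C1`, in a physicochemical assay for solubility, with a stated time of 3 days, at pH 7 (on this read-out higher numbers stand for higher solubility and lower numbers for lower solubility), compound 1 gives "not determined" (no result reported).
compound 2, `NC(=O)c1ccc2[nH]c(-c3ccc(OCC4CCNCC4)cc3)nc2c1`, in this assay compound 2 gives > 400000 nM.
compound 3, `COc1ccc(CN2CCC(COc3ccc(-c4nc5cc(C(N)=O)ccc5[nH]4)cc3)CC2)cc1`, in this assay compound 3 gives "not determined" (no result reported).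

Compound 2 stands alone as the only one of the three with any reported read-out, and even that is a limit of the assay rather than a number. Its value sits at the limit of > 400000 nM in this assay, at which 1 of the 3 values shown sits, while compound 1 and compound 3 carry no result at all. No step between two measured compounds can therefore be drawn, and nothing among these three tells how the ether tail moves solubility.

Compound 4, `CC(=O)N1CCCCC1CCOc1ccc(-c2nc3cc(C(N)=O)ccc3[nH]2)cc1`, is the next one to be measured in this assay. It differs from compound 2 in one place: (1-acetylpiperidin-2-yl)methyl in place of piperidin-4-yl on a saturated chain carbon bound to an oxygen on an aromatic ring. For the measured compounds named here, since no measured step exists to anchor the change, the expectation rests on the limit of compound 2 alone. Compound 4 is expected to fall somewhat below that limit, with the estimated step of an at least 4.0-fold lower number from compound 2 to compound 4 (0.60 log units; beyond the scatter) pointing downward and beyond the usual scatter, though a result that again comes back only as a limit remains quite possible. The estimated solubility of compound 4 in this assay is 100000 nM, within a range from 20000 nM to 400000 nM.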

Compound 4, solubility: 193000 nM
Compound 4: middle estimate off by 1.9-fold (0.29 log units), on the low side, within the range that was stated.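

In this assay compound 4 gives 193000 nM, the only single number among the compounds shown, so the saturated chain carbon bound to an oxygen on an aromatic ring now carries a readable change: (1-acetylpiperidin-2-yl)methyl in place of piperidin-4-yl gives an at least 2.0-fold lower number from compound 2 to compound 4 (0.31 log units; beyond the scatter) and shows that this position tolerates a larger group, with 0 hydrogen-bond donors in place of 1, while solubility in this series remains in the same high region of the read-out. Compound 2 gives > 400000 nM, which is a limit of the assay and not a number. Going by these compounds, the true size of the step therefore stays open in one direction, and its reading rests on this limit: the limit of > 400000 nM in this assay, at which 1 of the 4 values shown sits.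

The steps involving compound 1 and compound 3 cannot be read, and this single step cannot separate the acetyl group on the ring nitrogen from the other differences in the tail. A 1-acetylpiperidin-4-yl group or an unacetylated piperidin-2-yl group at this place would be needed to tell these apart, and a carboxylic acid on the tail remains an open case as well.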